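This account rests on a few compounds, and the source may have more. Where it says the series, first, only, none or still open, it means among the compounds named here.

Compound 1 `Cc1cc(Nc2cc(-c3ccccc3)[nH]n2)n2nc(SCc3ccc(F)cc3)nc2n1` is the reference point of this set. In an ADME assay on GES1 cells (Homo sapiens) for inhibition, read by MTT assay, with a stated time of 72 h (a higher number here means a weaker inhibitor, a lower number a stronger inhibitor), compound 1 gives 35500 nM. Compound 2 `Cc1cc(Nc2cc(-c3cccs3)[nH]n2)n2nc(SCc3ccc(Br)cc3)nc2n1` gives 38700 nM in this assay, and compound 3 `Cc1cc(Nc2cc(-c3ccccc3)[nH]n2)n2nc(SCc3csc4ccccc34)nc2n1` gives 29200 nM; compound 1 thus holds the second highest of the three numbers, its nearest neighbour being compound 2 and its furthest compound 3, both gaps within the scatter. Within the data shown here, the only single-point step available, a 1.2-fold lower number from compound 1 to compound 3 (0.08 log units; within the scatter), is also within the scatter, so putting 1-benzothiophen-3-yl in place of 4-fluorophenyl on the saturated chain carbon bound to a sulfur left the read-out where it was. Compound 4 `CCCSc1nc2nc(C)cc(Nc3cc(-c4ccccc4)[nH]n3)n2n1` is not yet measured. It differs from compound 1 as follows: ethyl in place of 4-fluorophenyl on a saturated chain carbon bound to a sulfur. Among the measured compounds shown here, no measured step replaces 4-fluorophenyl at this place with ethyl, so the bearing of the earlier step is indirect: it shows only that this position has tolerated one change without movement beyond the scatter. On that basis no step beyond the scatter is expected, a 1.0-fold higher number from compound 1 to compound 4 (0.01 log units; within the scatter). Compound 4 is therefore estimated at 36000 nM in this assay, with a range from 15000 nM to 85000 nM.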

Compound 4, half-maximal inhibitory concentration: > 50000 nM
Compound 4: no number, only a limit; the forecaster's own chance of this, stated with the estimate: 15%; middle value at least 1.3-fold (0.14 log units) from the limit.
By their numbers in this assay, from the lowest: compounds 3, 1 and 2 (each within the scatter of the next). At a limit, above all of these: compound 4.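

Compound 4 gives a limit of the assay and not a number: the limit of > 50000 nM in this assay, at which 1 of the 4 values shown sits.

Against the two compounds that differ from it in one place, the steps read as an at least 1.4-fold higher number from compound 1 to compound 4 (0.14 log units; that floor lies within the scatter) and an at least 1.7-fold higher number from compound 3 to compound 4 (0.23 log units; that floor lies within the scatter), so neither is shown to lie beyond the scatter, and each is bounded on one side only. Unlike the earlier step at this place, which exchanged one ring group for another, the change to ethyl removes the ring and gives a result that cannot be placed within the scatter of compound 1 or shown to lie outside it.

From the compounds shown here alone, the actual size of both steps stays open, and with it whether the loss of the ring moves the read-out at all. Also open, going by these compounds, is how a longer chain, or an amine or a carboxylic acid on the chain, would read in this assay.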